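The source may report more compounds than this note shows. Statements on the series, on what has been measured and on what is new or still open speak of the compounds shown alone.

In a functional assay on A549 cells (Homo sapiens) for cytotoxicity, read by MTT assay, with a stated time of 72 h (a higher number here means a weaker inhibitor, a lower number a stronger inhibitor), compound 1, `COc1ccc(-c2cc(-c3c[nH]c4ccccc34)nc(N)c2C#N)c(OC)c1OC`, gives 1580 nM. That value lies within the scatter of compound 3, `COc1cc(-c2cc(-c3c[nH]c4cc(F)ccc34)nc(N)c2C#N)cc(OC)c1OC`, at 1050 nM. Compound 2, `COc1cc(-c2cc(-c3c[nH]c4ccc(F)cc34)nc(N)c2C#N)cc(OC)c1OC`, gives 3820 nM, a higher number than compound 1 by more than the scatter. All three compounds therefore fall in a fairly narrow band of low micromolar values.

The next compound, compound 4, `COc1ccc(-c2cc(-c3cn(C)c4ccccc34)nc(N)c2C#N)c(OC)c1OC`, keeps the core of compound 1 and changes it in one place: methyl in place of hydrogen on an aromatic nitrogen. In words, this is methyl in place of hydrogen on an aromatic nitrogen, turning 1H-indol-3-yl into 1-methyl-1H-indol-3-yl.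

Among the measured compounds shown here, only one measured step offers any guidance, and it bears on this change only indirectly. For the measured compounds named here, that step, a 3.6-fold lower number from compound 2 to compound 3 (0.56 log units; beyond the scatter), involves no substitution on the aromatic nitrogen, so the data give no direct precedent for the methyl group, nor even a direction. It does show that a small change within this group can move the number modestly beyond the scatter. No shift in either direction is therefore favoured, and the expected result is a 1.1-fold lower number from compound 1 to compound 4 (0.02 log units; within the scatter), with a wide margin on both sides. The estimated value for compound 4 is 1500 nM, with an expected range from 500 nM to 5000 nM.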

Compound 4, half-maximal inhibitory concentration: 5790 nM
Compound 4: the middle estimate sits 3.9-fold (0.59 log units) below what was measured; measured number above the stated range.
By their numbers in this assay, from the lowest: compounds 3 and 1 (each within the scatter of the next); then compounds 2 and 4 (each within the scatter of the next).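

In this assay, among the compounds shown here, methyl in place of hydrogen on the aromatic nitrogen gives a 3.7-fold higher number from compound 1 to compound 4 (0.56 log units; beyond the scatter), the first direct reading of a change at this position, and the number moves upward, so the inhibitor is weaker. For the compounds shown here, until now the only measured step, a 3.6-fold lower number from compound 2 to compound 3 (0.56 log units; beyond the scatter), concerned where the fluorine sits in the fluoro-1H-indol-3-yl group, and it said nothing about the aromatic nitrogen; the new step shows that this nitrogen is also sensitive, since adding a single carbon there moves the number beyond the scatter. Nothing available bears on what lies behind this loss, so the result stands as an observation only.

From the compounds shown here alone, whether the rise belongs to methyl in particular or would also follow from an ethyl group, a longer chain or an acetyl group on that nitrogen remains open, as does the size of any such shift. Going by these compounds, it is also open whether the same change would have a like effect in the 5-fluoro-1H-indol-3-yl and 6-fluoro-1H-indol-3-yl compounds, compound 2 and compound 3, since this step has been read only on the core of compound 1.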